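Swapping Cyclopentyl for Butyl: Expected Cytotoxicity of Compound 4

The source may report more compounds than this note shows. Statements on the series, on what has been measured and on what is new or still open speak of the compounds shown alone.

Compound 3, `Nc1nc(NC2CCCC2)c2ncn(/C=C3/CC3(CO)CO)c2n1`, stands in an ADME assay on HFF cells (Homo sapiens) for cytotoxicity, with a stated time of 8 days (a lower number here means that less compound is tolerated, a higher number that more compound is tolerated), at a limit of the assay: compound 3 gives > 300000 nM, which is a limit rather than a number. Compound 1, `C=CCOc1nc(N)nc2c1ncn2/C=C1/CC1(CO)CO`, gives > 300000 nM in this assay, again a limit. Compound 2, `Nc1nc(OCc2ccccc2)c2ncn(/C=C3/CC3(CO)CO)c2n1`, gives > 300000 nM, likewise a limit. All three values thus sit at the limit of > 300000 nM in this assay, at which 3 of the 3 values shown sit. Compound 4, `CCCCNc1nc(N)nc2c1ncn2/C=C1/CC1(CO)CO`, differs from compound 3 by butyl in place of cyclopentyl on a nitrogen on an aromatic ring. Among the compounds with values here, the steps that bear on it are a step that the two limits leave unreadable from compound 1 to compound 3, a step that the two limits leave unreadable from compound 2 to compound 3 and a step that the two limits leave unreadable from compound 1 to compound 2, none of which has a readable size. With no direction to draw from, compound 4 is expected to stay at the limit, a step that the limit leaves unreadable from compound 3 to compound 4 meaning nothing beyond the scatter. Compound 4 is therefore estimated at 400000 nM, within 200000 nM to 1500000 nM.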

Compound 4, half-maximal cytotoxic concentration: > 300000 nM
Compound 4: no number, only a limit; the forecaster's own chance of this, stated with the estimate: 85%; the middle value is on the limit's open side.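

In this assay compound 4 gives > 300000 nM, which is a limit and not a number, so no step between compound 4 and compound 1, compound 2 or compound 3 can be read: the limit of > 300000 nM in this assay, at which 4 of the 4 values shown sit.

Going by these compounds, how much of each compound the cells tolerate, and whether the groups on the shared core change that, stays open.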